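Removing a Chloro Group in a Cytotoxicity Series

The source may report more compounds than this note shows. Statements on the series, on what has been measured and on what is new or still open speak of the compounds shown alone.

Of the compounds shown here, three from one series have been tested in an ADME assay on MCF-10A cells (Homo sapiens) for cytotoxicity, read by sulforhodamine B assay, with a stated time of 48 h; a higher number here means a weaker inhibitor of growth, a lower number a stronger inhibitor of growth. Compound 1 `Cc1ccc2nc(/N=C3\C(=O)N(CN(c4ccccc4)c4ccccc4)c4cccc(Cl)c43)sc2c1` gives 70000 nM in this assay, the highest of the three numbers. Compound 2 `Cc1ccc2nc(/N=C3\C(=O)N(CN(C)C)c4ccccc43)sc2c1` gives 13400 nM in this assay, and compound 3 `Cc1ccc2nc(/N=C3\C(=O)N(CN(C)C)c4cccc(Cl)c43)sc2c1` gives 7020 nM in this assay. Compound 3 and compound 2 differ in one place: hydrogen in place of chloro on an aromatic carbon. The measured step is a 1.9-fold higher number from compound 3 to compound 2 (0.28 log units; within the scatter). Compound 1 and compound 3 differ by a larger part of the molecule, and the difference between the two cores is not broken down here; their two values show compound 1 with the higher number, a gap beyond the scatter.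

Compound 4 `Cc1ccc2nc(/N=C3\C(=O)N(CN(c4ccccc4)c4ccccc4)c4ccccc43)sc2c1` has not yet been measured in this assay. It differs from compound 1 in the same way that compound 2 differs from compound 3: hydrogen in place of chloro on an aromatic carbon. The same change is thus made a second time, now on the core of compound 1 rather than the core of compound 3. Any expectation for compound 4 rests on compound 3 and compound 2 because a 1.9-fold higher number from compound 3 to compound 2 (0.28 log units; within the scatter) is the only measured example of this change, and it stayed within the scatter. Compound 4 is therefore expected to give about 110000 nM in this assay, with a likely range from 50000 nM to 250000 nM. For compound 4 this estimate corresponds to an expected step of a 1.6-fold higher number from compound 1 to compound 4 (0.20 log units; within the scatter). Since compound 1 already stands at the high end, the assay may report only a limit for compound 4 rather than a number.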

Compound 4, concentration for 50% growth inhibition: 34000 nM
Beside the measured number, compound 4's estimate is 3.2-fold (0.51 log units) above it; measured number outside the range, below it.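

In this assay, putting hydrogen in place of chloro on the core of compound 1 gives a 2.1-fold lower number from compound 1 to compound 4 (0.31 log units; beyond the scatter), a modest step that lies just beyond the scatter. The change therefore does not carry over unchanged from one core to the other, and the two cores give steps that differ by more than the scatter allows: the same change on two cores in this assay, a 1.9-fold higher number (0.28 log units; within the scatter) from compound 3 to compound 2 and a 2.1-fold lower number (0.31 log units; beyond the scatter) from compound 1 to compound 4, 3.9-fold (0.59 log units) apart, beyond the scatter of two such steps. This rests on a single pair of compounds on each core, so it shows that the result of removing the chloro group depends on the core in this series, but it does not show why, how large the step would be on any further core, or that the direction seen on the core of compound 1 would hold elsewhere.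

The compounds shown leave open whether the gap between the two steps follows the diphenylamino group itself, which could be tested with another amine such as piperidine or morpholine in its place on the chloro and hydrogen forms. They also leave open how fluoro, bromo or methoxy in place of chloro on the same aromatic carbon would read on each of the two cores.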